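A few compounds are considered here, and "the series" means these few. Any claim that something is new, unique, unknown or untested is made for them only; others in the source may bear on it.

Measured so far in an assay for inhibition of Amine oxidase [flavin-containing] B (Homo sapiens), read by fluorescence, using microsomes, with a stated time of 15 min; a lower number here means a stronger inhibitor, a higher number a weaker inhibitor:

compound 1, `Cc1ccccc1NC(=O)c1cc2ccccc2oc1=O` — 2960 nM
compound 2, `COc1ccccc1NC(=O)c1cc2ccccc2oc1=O` — 35400 nM
compound 3, `O=C(Nc1cccc(C(F)(F)F)c1)c1cc2cc(Br)cc(Br)c2oc1=O` — 7090 nM

Compound 2 stands at the highest of the three numbers in this assay. Within the data shown here, its nearest neighbour is compound 3, whose value lies lower, but compound 3 differs from compound 2 in more than one place, so no single step connects the two. Among the measured compounds shown here, the one single-place step recorded, a 12-fold higher number from compound 1 to compound 2 (1.08 log units; beyond the scatter), is large and concerns methoxy in place of methyl on the aromatic carbon of the anilide part.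

Compound 4, `COc1ccccc1NC(=O)c1cc2cc([N+](=O)[O-])ccc2oc1=O`, has not yet been measured. It differs from compound 2 by nitro in place of hydrogen on an aromatic carbon. For the measured compounds named here, no measured step touches this position of the shared core: the recorded step lies on the anilide ring, and compound 3 carries its core substituents alongside a different anilide. There is thus no direct guide to the size or direction of the change. Compound 4 is therefore expected to give roughly 20000 nM in this assay, within 5000 nM to 80000 nM. The expected step of a 1.8-fold lower number from compound 2 to compound 4 (0.25 log units; within the scatter) is accordingly taken as modest, with wide uncertainty.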

Compound 4, half-maximal inhibitory concentration: 50000 nM
Beside the measured number, compound 4's estimate is 2.5-fold (0.40 log units) below it; the measured number falls inside the stated range.
By their numbers in this assay, from the lowest: compound 1; then compound 3; then compounds 2 and 4 (each within the scatter of the next).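

In this assay, among these compounds, nitro in place of hydrogen on an aromatic carbon of the shared core gives a 1.4-fold higher number from compound 2 to compound 4 (0.15 log units; within the scatter) and is the only single-place step read on the core rather than on the anilide part. Whereas the anilide change gives a 12-fold higher number from compound 1 to compound 2 (1.08 log units; beyond the scatter) and lies beyond the scatter, compound 2 and compound 4 stand within the scatter of each other, so this position carries nitro, with its added heavy atoms, without a separation in this assay. No measurement is at hand that would explain this result.

As far as these compounds go, whether an amine or a carboxylic acid at this same position would also leave the number within the scatter remains open. So does whether nitro would read the same on the methyl-bearing anilide of compound 1, which gives 2960 nM in this assay without that group.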